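Notes on the thioether series: from compound 2 to compound 3

The source may hold more compounds than are shown below. What is called first, only, known or untested is meant among the compounds shown, and "the series" means these compounds.

The series is read in a functional assay on MKN-45 cells (Homo sapiens) for cytotoxicity, read by MTT assay, with a stated time of 48 h; a lower number here means a stronger inhibitor, a higher number a weaker inhibitor. Compound 1 `CCc1nnc(SCC(=O)c2ccccc2)n1N1C(=O)c2ccccc2C1=O` gives > 200000 nM, which is a limit of the assay and not a number. Compound 2 `COc1cc(-c2nnc(SC)n2N2C(=O)c3ccccc3C2=O)cc(OC)c1OC` likewise gives > 200000 nM, again a limit rather than a number. Both results sit at the limit of > 200000 nM in this assay, at which 2 of the 2 values shown sit, so compound 2 stands at the same limit as compound 1. Compound 3 `COc1cc(-c2nnc(SCC(=O)c3ccc(Br)cc3)n2N2C(=O)c3ccccc3C2=O)cc(OC)c1OC` differs from compound 2 by (4-bromophenyl)carbonyl in place of hydrogen on a saturated chain carbon bound to a sulfur. Among the measured compounds shown here, no step between measured compounds is available, so the size of this change cannot be calibrated. Compound 3 is expected to remain weak, with the step from compound 2 estimated as an at least 1.3-fold lower number from compound 2 to compound 3 (0.12 log units; that floor lies within the scatter). Compound 3 is estimated at 150000 nM, within 50000 nM to 300000 nM.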

Compound 3, half-maximal inhibitory concentration: 22300 nM
Compound 3: middle estimate off by 6.7-fold (0.83 log units), on the high side; measured number below the stated range.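

Among the compounds shown here, on the saturated chain carbon bound to a sulfur, (4-bromophenyl)carbonyl in place of hydrogen gives the first number of the series that is not a limit in this assay, with an at least 8.9-fold lower number from compound 2 to compound 3 (0.95 log units; beyond the scatter). For the compounds shown here, this position therefore responds to substitution, which the earlier compounds, both at a limit, could not show. The step is a floor and not a full size, since the value of compound 2 is a limit: the limit of > 200000 nM in this assay, at which 2 of the 3 values shown sit.

As far as these compounds go, whether the carbonyl, the ring or the bromine carries the step stays open. From the compounds shown here alone, how an amine or a carboxylic acid at this place would read also stays open.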